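This account rests on a few compounds, and the source may have more. Where it says the series, first, only, none or still open, it means among the compounds named here.

In an assay on isolated protein for inhibition of high affinity nerve growth factor receptor (Homo sapiens) (a lower number here means a stronger inhibitor, a higher number a weaker inhibitor), compound 1 `Cc1ccc(Sc2cnc(Nc3ccccn3)s2)cc1C(=O)NC(C)C` gives 2000 nM, compound 2 `Cc1ccc(Sc2cnc(Nc3cccc(Br)n3)s2)cc1C(=O)N(C)CC#N` gives 2 nM, and compound 3 `Cc1ccc(Sc2cnc(Nc3cccc(Br)n3)s2)cc1C(=O)N(C)CCC#N` gives 10 nM. Compound 3 thus stands second highest of the three numbers, nearest to compound 2 and furthest from compound 1. The only single-point step among these three is a 5.0-fold higher number from compound 2 to compound 3 (0.70 log units; beyond the scatter), a modest rise. Compound 4 `CCC(=O)N1CCN(C(=O)c2cc(Sc3cnc(Nc4cccc(Br)n4)s3)ccc2C)CC1` differs from compound 3 by 4-propanoylpiperazin-1-yl in place of (2-cyanoethyl)(methyl)amino on a carbonyl carbon. Within the data shown here, this is a larger rebuild of the amide substituent than the step from compound 2 to compound 3, and no measured pair shows a cyclic tertiary amide of this kind at that position, so the measured step is only a loose guide: it shows that growing the amide substituent by a small amount costs potency, but nothing about a ring of this size. The shared core of compound 3, with its bromopyridine, is kept in compound 4. A further modest loss is therefore expected, with wide uncertainty, and the step of a 3.0-fold higher number from compound 3 to compound 4 (0.48 log units; beyond the scatter) is the estimated outcome. Compound 4 is expected to give 30 nM in this assay, within a range of 5 nM to 200 nM.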

Compound 4, half-maximal inhibitory concentration: 21 nM
The estimate for compound 4 lay 1.4-fold (0.15 log units) above the measured number, and the stated range covers the measured number.
By their numbers in this assay, from the lowest: compound 2; then compound 3; then compound 4; then compound 1.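

In this assay, 4-propanoylpiperazin-1-yl in place of (2-cyanoethyl)(methyl)amino on a carbonyl carbon gives a 2.1-fold higher number from compound 3 to compound 4 (0.32 log units; beyond the scatter), while the same group in place of (cyanomethyl)(methyl)amino gives an 11-fold higher number from compound 2 to compound 4 (1.02 log units; beyond the scatter). Until now this position had shown only open chains ending in a nitrile, and compound 4, at 21 nM, shows that neither the open chain nor the nitrile is required for a number like this one. The ring, though the larger group, lies only a modest step from the longer nitrile chain and a large step from the shorter one. Nothing given here accounts for the size of these steps. The compounds shown leave open how a morpholine ring, or a piperazine ring carrying a free amine in place of the propanoyl group, would read at this carbonyl carbon. They also leave open whether the ring or its propanoyl group sets the number of compound 4.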